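The source may hold more compounds than are shown below. What is called first, only, known or untested is meant among the compounds shown, and "the series" means these compounds.

In a functional assay on HL-60 cells (Homo sapiens) for cytotoxicity, read by XTT assay, with a stated time of 3 days (on this read-out higher numbers stand for weaker inhibition and lower numbers for stronger inhibition), compound 1 `OC[C@H]1O[C@@H](n2cc(F)c3c(-c4ccco4)ncnc32)[C@H](O)[C@@H]1O` gives 1200 nM and compound 2 `OC[C@H]1O[C@@H](n2cc(Cl)c3c(-c4ccccc4)ncnc32)[C@H](O)[C@@H]1O` gives 1200 nM. Compound 2 therefore stands level with compound 1, and with only these two measurements, neither can be called the stronger. Compound 3 `OC[C@H]1O[C@@H](n2cc(Cl)c3c(-c4ccco4)ncnc32)[C@H](O)[C@@H]1O` keeps the rest of compound 2 and makes one structural change: furan-2-yl in place of phenyl on an aromatic carbon. In words, furan-2-yl sits in place of phenyl on an aromatic carbon.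

For the measured compounds named here, no two measured compounds differ in just one place, so the effect of this swap in this assay has not been seen directly, and any forecast is uncertain. Compound 1 also carries furan-2-yl, and its value of 1200 nM gives no hint of a large jump in either direction. A small move towards stronger inhibition is a cautious lean rather than a firm finding, and a result within the scatter of compound 2 would be no surprise. The expected change is a 2.4-fold lower number from compound 2 to compound 3 (0.38 log units; beyond the scatter). For compound 3, the estimated value is 500 nM, with an expected range of 90 nM to 2500 nM.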

Compound 3, half-maximal inhibitory concentration: 21600 nM
For compound 3 the middle estimate is 43-fold (1.64 log units) below the measured one, and the stated range ends below it.
By their numbers in this assay, from the lowest: compounds 1 and 2 (each within the scatter of the next); then compound 3.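

In this assay, the aromatic carbon next to the ring nitrogen proves sensitive to which aromatic ring it carries: with chloro kept on the core, furan-2-yl in place of phenyl gives an 18-fold higher number from compound 2 to compound 3 (1.26 log units; beyond the scatter), which means much weaker inhibition. The halogen matters just as clearly, since with furan-2-yl kept, chloro in place of fluoro gives an 18-fold higher number from compound 1 to compound 3 (1.26 log units; beyond the scatter), so a change of one atom on the core can shift the result as far as exchanging the whole aromatic ring. Compound 3 is therefore the weakest of the three, and nothing available here explains either step.

As far as these compounds go, it remains open whether furan-2-yl would also weaken inhibition relative to phenyl with fluoro on the core, or whether the large step depends on the presence of chloro. From the compounds shown here alone, it is equally open how bromo in place of chloro, or an amine or a methyl group in place of the aromatic ring, would compare on these same cells.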